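Swapping the triazole aryl: ethoxyphenyl to dimethylphenyl

This account rests on a few compounds, and the source may have more. Where it says the series, first, only, none or still open, it means among the compounds named here.

Measured compounds:
compound 1 `N#CC1=C(N)Oc2c(c3nc4ccccc4nc3c3ccccc23)C12C(=O)N(Cc1cnnn1-c1ccc(Cl)cc1)c1ccccc12`: > 50000 nM
compound 2 `CCOc1ccc(-n2nncc2CN2C(=O)C3(C(C#N)=C(N)Oc4c3c3nc5ccccc5nc3c3ccccc43)c3ccccc32)cc1`: > 50000 nM

Both of these values are limits of a functional assay on HCT-116 cells (Homo sapiens) for antiproliferative activity, read by MTT assay, with a stated time of 48 h (on this read-out lower numbers stand for stronger inhibition and higher numbers for weaker inhibition), not numbers. Among the measured compounds shown here, compound 2 therefore stands at the limit, and the one other value shown sits there too (the limit of > 50000 nM in this assay, at which 2 of the 2 values shown sit). For the measured compounds named here, the single measured step, a step that the two limits leave unreadable from compound 1 to compound 2, is a change of ethoxy in place of chloro on an aromatic carbon whose size the two limits leave unreadable.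

Compound 3 `Cc1ccc(-n2nncc2CN2C(=O)C3(C(C#N)=C(N)Oc4c3c3nc5ccccc5nc3c3ccccc43)c3ccccc32)c(C)c1` differs from compound 2 by 2,4-dimethylphenyl in place of 4-ethoxyphenyl on an aromatic nitrogen. The step from compound 1 to compound 2 is the only one that bears on this change, and it shows nothing more than that altering the substituent on this phenyl ring left the value at the limit. No step beyond the scatter is expected in this assay , and compound 3 is expected to remain at the limit as well. For compound 3 the estimate is 70000 nM, with a range from 25000 nM to 200000 nM. The expected step is thus a step that the limit leaves unreadable from compound 2 to compound 3, essentially none.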

Compound 3, half-maximal inhibitory concentration: > 50000 nM
Compound 3: no number, only a limit; the forecaster's own chance of this, stated with the estimate: 80%; the middle value lies beyond the limit too.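

Compound 3, like compound 1 and compound 2, gives only a limit in this assay, so no step among these three compounds can be read: the limit of > 50000 nM in this assay, at which 3 of the 3 values shown sit.

The compounds shown leave open whether the aryl group on the aromatic nitrogen changes antiproliferative activity at all.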